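The source may hold more compounds than are shown below. What is called first, only, known or untested is meant among the compounds shown, and "the series" means these compounds.

Measured in a functional assay on K562 cells (Homo sapiens), read by MTT assay, with a stated time of 72 h; on this read-out higher numbers stand for weaker inhibition and lower numbers for stronger inhibition:

Compound 1 `COc1ncnc2c1c(-c1ccoc1)cn2[C@@H]1O[C@H](CO)[C@@H](O)[C@H]1O` gives 2820 nM.
Compound 2 `CSc1ncnc2c1c(-c1ccccc1)cn2[C@@H]1O[C@H](CO)[C@@H](O)[C@H]1O` gives > 20000 nM, a limit of the assay rather than a number.
Compound 3 `CNc1ncnc2c1c(-c1ccccc1)cn2[C@@H]1O[C@H](CO)[C@@H](O)[C@H]1O` gives > 20000 nM, again a limit of the assay.

Compound 2 therefore stands at the limit of > 20000 nM in this assay, at which 2 of the 3 values shown sit, and nothing more than that limit is known of it in this assay. Among the compounds with values here, the only step between measured compounds, a step that the two limits leave unreadable from compound 2 to compound 3, is unreadable, since both ends are limits. The step now followed leads to compound 4 `CSc1ncnc2c1c(-c1ccoc1)cn2[C@@H]1O[C@H](CO)[C@@H](O)[C@H]1O`, and the change is furan-3-yl in place of phenyl on an aromatic carbon. Within the data shown here, no measured step covers this change. What can be said is that compound 1, which carries furan-3-yl together with methoxy, gives a number in this assay, whereas compound 2, which carries phenyl together with methylsulfanyl, gives only a limit; no step between compound 1 and compound 4 is shown, so the two values are merely set side by side. On that basis compound 4 is expected to fall somewhere between the limit of compound 2 and the value of compound 1, with a real chance that it, too, is reported only as a limit. The estimate for compound 4 is 9000 nM, ranging from 2500 nM to 30000 nM. This estimate means an expected step of an at least 2.2-fold lower number from compound 2 to compound 4 (0.34 log units; beyond the scatter), toward stronger inhibition, but of uncertain size.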

Compound 4, half-maximal inhibitory concentration: 3250 nM
For compound 4 the middle estimate is 2.8-fold (0.44 log units) above the measured one; low and high end bracket the measured number.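

In this assay, furan-3-yl in place of phenyl on this aromatic carbon of the five-membered ring takes the compound from a limit to a readable number, toward stronger inhibition: the change gives an at least 6.1-fold lower number from compound 2 to compound 4 (0.78 log units; beyond the scatter). On these data alone, the true size of that step stays unknown, since compound 2 is known only through a limit of the assay: the limit of > 20000 nM in this assay, at which 2 of the 4 values shown sit. The other new step, a 1.2-fold higher number from compound 1 to compound 4 (0.06 log units; within the scatter), adds that with furan-3-yl in place, methylsulfanyl and methoxy cannot be told apart in this assay.

The compounds shown do not separate what furan-3-yl brings: its ring is smaller than phenyl and it holds an oxygen, and a furan-2-yl or thiophen-3-yl group at the same place would be needed to tell these apart. As far as these compounds go, it also stays open whether methylamino, seen so far only with phenyl in compound 3, would give a readable number when paired with furan-3-yl.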